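Amide-end variation on a shared core: carboxyphenyl in place of oxazolyl

The source may report more compounds than this note shows. Statements on the series, on what has been measured and on what is new or still open speak of the compounds shown alone.

Three compounds of this set share one core and differ only in the group carried on the carbonyl carbon of the outer amide. Compound 1 `CCc1ccc(C(=O)Nc2cccc(NC(=O)COc3ccc4c(=O)ccoc4c3)c2)cc1` gives 235 nM in an assay on isolated protein for inhibition of Rho-associated protein kinase 1 (Homo sapiens), read by scintillation counting, radiometric assay and 33P incorporation, with a stated time of 40 min, in the presence of a further agent that is not named here; on this read-out lower numbers stand for stronger inhibition and higher numbers for weaker inhibition. Compound 2 `O=C(COc1ccc2c(=O)ccoc2c1)Nc1cccc(NC(=O)c2ccc(F)cc2)c1` gives 129 nM. Compound 3 `CC(C)(C)c1cc(C(=O)Nc2cccc(NC(=O)COc3ccc4c(=O)ccoc4c3)c2)no1` gives 101 nM, the lowest of the three numbers; its step of a 2.3-fold lower number from compound 1 to compound 3 (0.37 log units; beyond the scatter) is beyond the scatter, while a 1.3-fold lower number from compound 2 to compound 3 (0.11 log units; within the scatter) is within it, and a 1.8-fold lower number from compound 1 to compound 2 (0.26 log units; within the scatter) is also within it. For the measured compounds named here, all exchanges at this position so far have moved the number only a little.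

Compound 4 `O=C(COc1ccc2c(=O)ccoc2c1)Nc1cccc(NC(=O)c2ccc(C(=O)O)cc2)c1` is not yet measured. It differs from compound 3 by 4-carboxyphenyl in place of 5-(tert-butyl)-1,2-oxazol-3-yl on a carbonyl carbon. Going by the values given here, the steps that bear on this exchange are the three just given, each small. A step of similar size is therefore expected, with no direction clearly favoured; compound 4 is estimated at 160 nM, between 50 nM and 500 nM, which means an expected step of a 1.6-fold higher number from compound 3 to compound 4 (0.20 log units; within the scatter).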

Compound 4, half-maximal inhibitory concentration: 6890 nM
Beside the measured number, compound 4's estimate is 43-fold (1.63 log units) below it, outside the stated range (above it).
By their numbers in this assay, from the lowest: compounds 3, 2 and 1 (each within the scatter of the next, the first and the last beyond it); then compound 4.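

The position on the carbonyl carbon of the outer amide is less forgiving than the earlier exchanges suggested: in this assay 4-carboxyphenyl in place of 5-(tert-butyl)-1,2-oxazol-3-yl gives a 68-fold higher number from compound 3 to compound 4 (1.83 log units; beyond the scatter) and is a large step. On the same aromatic carbon of the phenyl series, carboxy in place of fluoro gives a 53-fold higher number from compound 2 to compound 4 (1.73 log units; beyond the scatter) and carboxy in place of ethyl gives a 29-fold higher number from compound 1 to compound 4 (1.47 log units; beyond the scatter), so fluoro and ethyl stay close to each other while carboxy stands far from both. Nothing at hand accounts for this loss.

The compounds shown leave open whether the loss belongs to the free carboxylic acid itself or would persist with a methyl ester, a primary amide or an amine on that carbon. Also open, going by these compounds, is whether a longer chain carrying the carboxylic acid, such as carboxymethyl, behaves the same way.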